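Dihydroxyphenyl in place of dichlorophenyl on the shared core

A few compounds are considered here, and "the series" means these few. Any claim that something is new, unique, unknown or untested is made for them only; others in the source may bear on it.

Compound 1 `COc1cccc(/C=C2\CCC/C(=C\c3ccccc3Cl)C2=O)c1OC` and compound 2 `COc1cccc(/C=C2\CCC/C(=C\c3cccc(Cl)c3Cl)C2=O)c1OC` share one core and differ by a chloro in place of hydrogen on an aromatic carbon. In an ADME assay on NHDF cells (Homo sapiens) for cytotoxicity, read by MTT assay, with a stated time of 72 h (on this read-out higher numbers stand for weaker inhibition and lower numbers for stronger inhibition), compound 1 gives 44200 nM. For compound 2 this assay reports only a limit, > 50000 nM; this is the limit of > 50000 nM in this assay, at which 1 of the 2 values shown sits. Hence the step of an at least 1.1-fold higher number from compound 1 to compound 2 (0.05 log units; that floor lies within the scatter) has only a floor. Compound 3 `COc1cccc(/C=C2\CCC/C(=C\c3ccc(O)c(O)c3)C2=O)c1OC` carries 3,4-dihydroxyphenyl in place of 2,3-dichlorophenyl on a double-bonded chain carbon bound to a double-bonded ring carbon. Among the measured compounds shown here, no measured step bears on this exchange, so nothing sizes it; compound 2 sits at the limit, which leaves weak inhibition as the only anchor. Compound 3 is expected near 40000 nM in this assay, within 15000 nM to 100000 nM. The implied step an at least 1.2-fold lower number from compound 2 to compound 3 (0.09 log units; that floor lies within the scatter) is an estimate only.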

Compound 3, half-maximal inhibitory concentration: 17900 nM
Compound 3: middle estimate off by 2.2-fold (0.35 log units), on the high side, and the stated range covers the measured number.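

In this assay, the place on a double-bonded chain carbon bound to a double-bonded ring carbon tolerates a change that moves the read-out beyond the scatter: 3,4-dihydroxyphenyl gives an at least 2.7-fold lower number from compound 2 to compound 3 (0.44 log units; beyond the scatter) and a 2.5-fold lower number from compound 1 to compound 3 (0.39 log units; beyond the scatter), whereas the chloro exchange alone showed only a floor within the scatter. The first of these steps is only a floor, because compound 2 stands at a limit: the limit of > 50000 nM in this assay, at which 1 of the 3 values shown sits.

As far as these compounds go, whether a single hydroxyl group on the phenyl ring would suffice remains open. So does the effect of an amine or a carboxylic acid at the same place.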